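The source may hold more compounds than are shown below. What is called first, only, known or untested is meant among the compounds shown, and "the series" means these compounds.

Measured so far in an ADME assay on HepG2 cells (Homo sapiens) for cytotoxicity, read by MTT assay (on this read-out higher numbers stand for weaker inhibition and lower numbers for stronger inhibition), each value a limit of the assay:

- compound 1 `O=C(NCc1ccccc1)Oc1ccc(Cl)cc1C(=O)Nc1ccc(Cl)cc1`: > 250000 nM
- compound 2 `O=C(NC1CCCCC1)Oc1ccc(Cl)cc1C(=O)Nc1ccc(Br)cc1`: > 50000 nM
- compound 3 `O=C(Nc1ccccc1)Oc1ccc(Cl)cc1C(=O)Nc1ccc(Cl)cc1`: > 250000 nM

Compound 3 stands at the limit of > 250000 nM in this assay, at which 2 of the 3 values shown sit, so it has no number. Compound 4 `O=C(NC1CCCCC1)Oc1ccc(Cl)cc1C(=O)Nc1ccc(Cl)cc1` carries cyclohexyl in place of phenyl on an amide-type nitrogen. Going by the values given here, the one measured step, a step that the two limits leave unreadable from compound 1 to compound 3, also changes the group on that nitrogen. Compound 2 carries cyclohexyl there too and sits at the limit of > 50000 nM in this assay, at which 1 of the 3 values shown sits. No readable step therefore bears on this change, and no shift beyond the scatter is expected in this assay. The expected a number no higher from compound 3 to compound 4 (the limit leaves the size open) is accordingly small. For compound 4 the estimated value is 250000 nM, with an expected range of 80000 nM to 600000 nM, most likely reported only as a limit.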

Compound 4, half-maximal inhibitory concentration: > 250000 nM
Compound 4: a limit, no number; the forecaster's own chance of this, stated with the estimate: 85%; the middle value sits exactly at the limit.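

In this assay compound 4 gives > 250000 nM, a limit and not a number, so its steps to compound 1, compound 2 and compound 3 cannot be read. The compounds shown leave open whether either the group on the amide-type nitrogen or chloro in place of bromo shifts the value at all.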